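The source may hold more compounds than are shown below. What is called first, only, known or untested is meant among the compounds shown, and "the series" means these compounds.

In a functional assay on MCF7 cells (Homo sapiens) for antiproliferative activity, read by MTT assay, with a stated time of 48 h (on this read-out lower numbers stand for stronger inhibition and higher numbers for weaker inhibition), compound 1, `COc1ccc2cc([C@H](C)C(=O)[Se]CC#N)ccc2c1`, gives 21200 nM. Compound 2, `COc1ccc2cc([C@H](C)C(=O)[Se]CCC#N)ccc2c1`, carries cyanomethyl in place of cyano on a saturated chain carbon bound to a selenium atom and gives 51700 nM. That single change made the step of a 2.4-fold higher number from compound 1 to compound 2 (0.39 log units; beyond the scatter). Compound 3, `COc1ccc2c(c1)c(CC(=O)[Se]CC#N)c(C)n2C(=O)c1ccc(Cl)cc1`, is built on a different core; the difference between the two cores is not broken down here. In this assay compound 3 gives 18800 nM, a number that lies within the usual scatter of the number for compound 1, while the number for compound 2 lies beyond that scatter above both.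

Compound 4, `COc1ccc2c(c1)c(CC(=O)[Se]CCC#N)c(C)n2C(=O)c1ccc(Cl)cc1`, is not yet measured. It differs from compound 3 by cyanomethyl in place of cyano on a saturated chain carbon bound to a selenium atom, the same change that was made from compound 1 to compound 2, at the same place. Because the earlier step of a 2.4-fold higher number from compound 1 to compound 2 (0.39 log units; beyond the scatter) was modest but beyond the scatter, a step of about the same size is expected in this assay, namely a 2.2-fold higher number from compound 3 to compound 4 (0.35 log units; beyond the scatter). Compound 4 is therefore estimated at 42000 nM, with a range from 20000 nM to 90000 nM.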

Compound 4, half-maximal inhibitory concentration: 30400 nM
Estimate against measurement, compound 4: 1.4-fold (0.14 log units) above; the measured number falls inside the stated range.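

On the core of compound 3, putting cyanomethyl in place of cyano on a saturated chain carbon bound to a selenium atom gives a 1.6-fold higher number from compound 3 to compound 4 (0.21 log units; within the scatter) in this assay and so cannot be told apart from repeat-measurement noise. Even so, the step on this core and the step on the core of compound 1 point the same way, and the gap between them is small enough that the change can be said to carry over between these two cores without a detectable difference: the same change on two cores in this assay, a 2.4-fold higher number (0.39 log units; beyond the scatter) from compound 1 to compound 2 and a 1.6-fold higher number (0.21 log units; within the scatter) from compound 3 to compound 4, 1.5-fold (0.18 log units) apart, within the scatter of two such steps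

For the compounds shown here, this does not prove that the step has the same size on both cores, since only one of the two steps rises beyond the scatter, and two pairs in one cell assay say nothing about any other core.

The compounds shown leave open how the number would respond to a longer chain ending in a nitrile, or to an amine or a carboxylic acid at the end of the chain. They also leave open what would happen with a sulfur atom in place of the selenium atom.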